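Swapping an imidazoline for an imidazole on two cores

The source may hold more compounds than are shown below. What is called first, only, known or untested is meant among the compounds shown, and "the series" means these compounds.

Compound 1 `CCN(CC)C(=O)c1ccccc1OCC1=NCCN1`: in a functional assay for activation of Alpha-1B adrenergic receptor (Homo sapiens) (on this read-out higher numbers stand for an effect only at larger amounts of compound and lower numbers for an effect already at smaller amounts), compound 1 gives < 100000 nM, which is a limit of the assay rather than a number.
Compound 2 `CCN(CC)C(=O)c1ccccc1OCc1c[nH]cn1`: in this assay compound 2 gives < 100000 nM, again only a limit.
Compound 3 `c1ccc(N2CCCCC2)c(NCC2=NCCN2)c1`: in this assay compound 3 gives < 5020 nM, also a limit.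

The change from compound 1 to compound 2 is a group of 5 heavy atoms (3 carbon, 2 nitrogen; one five-membered aromatic ring with 2 hetero atoms) in place of a group of 5 heavy atoms (3 carbon, 2 nitrogen; one five-membered non-aromatic ring with 2 hetero atoms), on a saturated chain carbon bound to an oxygen on an aromatic ring. Its size is a step that the two limits leave unreadable from compound 1 to compound 2, and it stays unreadable because both compounds sit at the limit of < 100000 nM in this assay, at which 2 of the 3 values shown sit. How the core of compound 3 differs from the core of compound 1 is not broken down here; compound 3 sits at the limit of < 5020 nM in this assay, at which 1 of the 3 values shown sits.

Compound 4 `c1ccc(N2CCCCC2)c(NCc2c[nH]cn2)c1` is not yet measured. It differs from compound 3 by a group of 5 heavy atoms (3 carbon, 2 nitrogen; one five-membered aromatic ring with 2 hetero atoms) in place of a group of 5 heavy atoms (3 carbon, 2 nitrogen; one five-membered non-aromatic ring with 2 hetero atoms), on a saturated chain carbon bound to a nitrogen on an aromatic ring. The place is not the same word for word: in the first pair the carbon is bound to an oxygen on an aromatic ring, here to a nitrogen on an aromatic ring, so this is the same kind of change, not the same change.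

The step from compound 3 to compound 4 is expected to be an at least 3.9-fold higher number from compound 3 to compound 4 (0.60 log units; beyond the scatter). This expectation rests on a step that the two limits leave unreadable from compound 1 to compound 2 giving no readable size, and on compound 3 offering only a limit. Compound 4 is expected at 20000 nM, between 2000 nM and 200000 nM.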

Compound 4, half-maximal effective concentration: < 5020 nM
Compound 4: no number, only a limit; the forecaster's own chance of this, stated with the estimate: 70%; middle value at least 3.9-fold (0.60 log units) from the limit.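

No step can be read from compound 3 to compound 4, because the two compounds share one limit rather than giving numbers: the limit of < 5020 nM in this assay, at which 2 of the 4 values shown sit. What the compounds shown leave open is whether putting 1H-imidazol-4-yl in place of the five-membered non-aromatic ring changes the response in this assay on either core, and by how much.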